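Trimming the amine side chain of a weak kinase binder

This account rests on a few compounds, and the source may have more. Where it says the series, first, only, none or still open, it means among the compounds named here.

Two compounds have been measured in an assay on isolated protein for inhibition of tyrosine-protein kinase receptor UFO (Homo sapiens), with a stated time of 1.5 h; on this read-out higher numbers stand for weaker inhibition and lower numbers for stronger inhibition:
compound 1, `N#Cc1ccc(-n2cc(-c3n[nH]c4cc(Cl)c(N[C@@H]5CCNC5)cc34)cn2)cc1`: 700 nM
compound 2, `Cn1cc(-c2n[nH]c3ccc(N[C@@H]4CCNC4)cc23)cn1`: 37000 nM

Compound 2 has the highest number of the two; compound 1 sits far below it, beyond the usual scatter. Compound 3, `Cn1cc(-c2n[nH]c3ccc(N)cc23)cn1`, is not yet measured. It differs from compound 2 by hydrogen in place of pyrrolidin-3-yl on a nitrogen on an aromatic ring; the same difference, cut one bond further out, reads (pyrrolidin-3-yl)amino to amino. Among the measured compounds shown here, no measured pair covers this change. Compound 2 already gives 37000 nM. On that basis the step of a 2.4-fold higher number from compound 2 to compound 3 (0.39 log units; beyond the scatter) is expected to be modest, toward a weaker number if anything. Compound 3 is estimated at 90000 nM, within 30000 nM to 300000 nM.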

Compound 3, half-maximal inhibitory concentration: 8910 nM
Estimate against measurement, compound 3: 10-fold (1.00 log units) above; the whole stated range lies above it.
By their numbers in this assay, from the lowest: compound 1; then compound 3; then compound 2.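

In this assay, removing the pyrrolidin-3-yl group from the nitrogen on the aromatic ring gives a 4.2-fold lower number from compound 2 to compound 3 (0.62 log units; beyond the scatter). This pair therefore shows that the ring is not needed at this position: the plain amino group gives stronger inhibition than the (pyrrolidin-3-yl)amino group. Nothing available explains this shift. From the compounds shown here alone, whether a methyl or acetyl group on that nitrogen would keep this stronger inhibition remains open. So does whether the same change would have a similar effect on compound 1.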